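The source may hold more compounds than are shown below. What is called first, only, known or untested is meant among the compounds shown, and "the series" means these compounds.

Compound 1, `CCCC(Oc1ccc(-n2cc(OC)cn2)cc1)c1ccc(C(=O)NCCC(=O)O)cc1`: in a functional assay on cells for antagonist activity at Glucagon receptor (Homo sapiens), read by cAMP accumulation, in the presence of a further agent that is not named here (a higher number here means a weaker inhibitor, a lower number a stronger inhibitor), compound 1 reaches only the assay limit of > 23000 nM.
Compound 2, `CCCC(Oc1ccc(-n2cc(C#N)cn2)cc1)c1ccc(C(=O)NCCC(=O)O)cc1`: in this assay compound 2 reaches only the assay limit of > 50000 nM.
Compound 3, `CCCC(Oc1ccc(-n2cc(F)cn2)cc1)c1ccc(C(=O)NCCC(=O)O)cc1`: in this assay compound 3 gives 10000 nM.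

Among the three, compound 3 is the only one with a measured number; the other two stop at limits, namely the limit of > 23000 nM in this assay, at which 1 of the 3 values shown sits, and (the limit of > 50000 nM in this assay, at which 1 of the 3 values shown sits). Replacing methoxy by fluoro gives an at least 2.3-fold lower number from compound 1 to compound 3 (0.36 log units; beyond the scatter), and replacing cyano by fluoro gives an at least 5.0-fold lower number from compound 2 to compound 3 (0.69 log units; beyond the scatter), while a step that the two limits leave unreadable from compound 1 to compound 2 because both ends are limits.

Compound 4, `CCCC(Oc1ccc(-n2cc(Cl)cn2)cc1)c1ccc(C(=O)NCCC(=O)O)cc1`, differs from compound 3 by chloro in place of fluoro on an aromatic carbon. Going by the values given here, no measured step swaps one halogen for another; the steps that bear on this change are the two arriving at the fluoro group of compound 3, which only show that fluoro reads better than methoxy or cyano at this position. A change from one halogen to the next is expected to move the number little, so for compound 4 the expected step is a 1.4-fold lower number from compound 3 to compound 4 (0.15 log units; within the scatter), within the scatter. Compound 4 is therefore estimated at 7000 nM, with a range from 2500 nM to 25000 nM.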

Compound 4, antagonist equilibrium constant: 6500 nM
Estimate against measurement, compound 4: 1.1-fold (0.03 log units) above; low and high end bracket the measured number.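

Replacing 4-fluoro-1H-pyrazol-1-yl with 4-chloro-1H-pyrazol-1-yl gives a 1.5-fold lower number from compound 3 to compound 4 (0.19 log units; within the scatter) in this assay, so the two halogens cannot be told apart at this carbon. Chloro also reads better than the two non-halogen groups: changing cyano to chloro gives an at least 7.6-fold lower number from compound 2 to compound 4 (0.88 log units; beyond the scatter), and changing methoxy to chloro gives an at least 3.5-fold lower number from compound 1 to compound 4 (0.54 log units; beyond the scatter), so the advantage first seen with fluoro is now shared by a second halogen. Each of these two steps is open-ended because it starts from an assay limit and not from a number, for compound 2 and for compound 1 alike: the limit of > 23000 nM in this assay, at which 1 of the 4 values shown sits, and the limit of > 50000 nM in this assay, at which 1 of the 4 values shown sits.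

The compounds shown leave open whether bromo, methyl or an amine on this same carbon of the pyrazole would read like the two halogens or fall back towards methoxy and cyano. They also leave open whether the match between chloro and fluoro would hold with a longer chain in place of the propyl chain on the shared core.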